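From 2-bromobenzyl to 4-bromobenzyl

This account rests on a few compounds, and the source may have more. Where it says the series, first, only, none or still open, it means among the compounds named here.

Measured so far:
Compound 1 `COc1ccc(C(=O)CSc2nc(Cc3ccccc3Br)c(C)c(=O)[nH]2)cc1`: > 272000 nM (a limit of the assay)
Compound 2 `CCc1c(Cc2ccccc2Br)nc(SCC(=O)c2ccc(OC)cc2)[nH]c1=O`: 187000 nM

Both entries come from an ADME assay on MT4 cells (Homo sapiens) for cytotoxicity; a lower number here means that less compound is tolerated, a higher number that more compound is tolerated. The entry for compound 1 is a limit, not a number. Going by the values given here, that leaves compound 2 with the only actual number so far, 187000 nM.

Compound 3 `CCc1c(Cc2ccc(Br)cc2)nc(SCC(=O)c2ccc(OC)cc2)[nH]c1=O` has the same atoms as compound 2, joined differently: 4-bromophenyl in place of 2-bromophenyl on a saturated chain carbon bound to an aromatic carbon. Among the compounds with values here, the only measured step is an at least 1.4-fold lower number from compound 1 to compound 2 (0.16 log units; that floor lies within the scatter), and it is a different change from this one. Within the data shown here, with no measured step of this kind to go on, no shift beyond the scatter is expected in this assay, in either direction. The expected step is a 1.0-fold lower number from compound 2 to compound 3 (0.02 log units; within the scatter). The estimate for compound 3 is 180000 nM, within an expected range of 80000 nM to 350000 nM.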

Compound 3, half-maximal cytotoxic concentration: > 264000 nM
Compound 3 gave a limit, no number (the forecaster's own chance of this, stated with the estimate: 30%); at least 1.4-fold (0.16 log units) between middle value and limit.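

In this assay, putting 4-bromophenyl in place of 2-bromophenyl gives an at least 1.4-fold higher number from compound 2 to compound 3 (0.14 log units; that floor lies within the scatter), the first step read for this change on the saturated chain carbon bound to an aromatic carbon. Moving the bromine therefore gives no sign that the compound is less well tolerated, but it does not establish that it is better tolerated either. Going by these compounds, the true size of the step stays unknown because compound 3 gave a limit of the assay and not a number: the limit of > 264000 nM in this assay, at which 1 of the 3 values shown sits.

On these data alone, whether compound 3 truly differs from compound 2 by more than the usual scatter remains open. Also open, as far as these compounds go, is how a carboxylic acid or an amine in place of the bromine would behave in this assay on this same shared core.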